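From Methyl to Phenyl in a Thiophene Series

The source may report more compounds than this note shows. Statements on the series, on what has been measured and on what is new or still open speak of the compounds shown alone.

Of the compounds shown here, three have been tested in a functional assay on cells (Panel CNS (Carcinoma cell lines), Homo sapiens) for inhibition; a higher number here means a weaker inhibitor of growth, a lower number a stronger inhibitor of growth. Compound 1 `CN1C/C(=C\c2cccs2)C(O)/C(=C/c2cccs2)C1` reaches only a limit, > 100000 nM. Compound 2 `CN1C/C(=C\c2cccs2)C2=NN(C)C(c3cccs3)C2C1` gives 80700 nM. Compound 3 `Cc1ccc(/C=C2\CN(C)CC3C2=NN(c2ccccc2)C3c2ccc(C)cc2)cc1` gives 77000 nM, and this number lies within the usual scatter of the number for compound 2, so the two stand level.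

Compound 4 `CN1C/C(=C\c2cccs2)C2=NN(c3ccccc3)C(c3cccs3)C2C1` has not yet been measured. It differs from compound 2 in one place, with phenyl in place of methyl on an amine nitrogen in a ring. For the measured compounds named here, no measured pair isolates this change, so its size can only be judged indirectly. Compound 3 also has phenyl on an amine nitrogen in a ring, alongside other differences, and it gives 77000 nM. On that basis, no change beyond the scatter is expected in this assay. The expected step is a 1.3-fold lower number from compound 2 to compound 4 (0.13 log units; within the scatter). For compound 4 the estimated value is 60000 nM, with an expected range of 20000 nM to 100000 nM.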

Compound 4, concentration for 50% growth inhibition: 35700 nM
The estimate for compound 4 lay 1.7-fold (0.23 log units) above the measured number, and the stated range covers the measured number.
By their numbers in this assay, from the lowest: compound 4; then compounds 3 and 2 (each within the scatter of the next). At a limit, above all of these: compound 1.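

With phenyl in place of methyl on this amine nitrogen, this assay shows a 2.3-fold lower number from compound 2 to compound 4 (0.35 log units; beyond the scatter) and so this position responds to the change, modestly but beyond the scatter. Compound 3 carries phenyl here alongside other differences, so it could not separate this one change from the rest, whereas this pair does. Even so, compound 4 remains a weak inhibitor of growth in this assay, and the readable scale does not stretch far above it: the limit of > 100000 nM in this assay, at which 1 of the 4 values shown sits.

Going by these compounds, only methyl and phenyl appear at this position, so it remains open whether the gain belongs to the aromatic ring or would also come with a simple longer chain such as butyl. A benzyl group, or a phenyl ring carrying an amine, would test how far the trend extends.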